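The compounds below may be only part of what the source reports. "The series", "measured", "known", "first", "only" and "open" are said of these compounds alone.

Compound 1 `Nc1ccc(C(=O)/C=C/c2ccco2)cc1` and compound 2 `O=C(/C=C/c1ccco1)c1ccc(NC(=O)c2ccccc2)cc1` share one core, and the two differ only in the substituent on the ring nitrogen. In a functional assay on HT-29 cells (Homo sapiens) for cytotoxicity, read by resazurin assay, with a stated time of 48 h (a higher number here means that more compound is needed for the effect, a lower number that less compound is needed), compound 1 gives 28000 nM, and compound 2 gives 76000 nM. Within the data shown here, the one measured step, a 2.7-fold higher number from compound 1 to compound 2 (0.43 log units; beyond the scatter), leaves compound 2 with the highest of the two numbers seen so far, compound 1 being its only neighbour. The next compound, compound 3 `O=C(/C=C/c1cccc([N+](=O)[O-])c1)c1ccc(NC(=O)c2ccccc2)cc1`, keeps the benzoyl on the nitrogen and departs from compound 2 at the far end of the chain: 3-nitrophenyl in place of furan-2-yl on a double-bonded chain carbon bound to a double-bonded chain carbon. Among the measured compounds shown here, no measured step touches that end of the molecule; the single step at hand, a 2.7-fold higher number from compound 1 to compound 2 (0.43 log units; beyond the scatter), concerns the nitrogen substituent alone and carries no information about the furan-2-yl position. The expectation for compound 3 in this assay therefore rests on compound 2 by itself, and it is for no step beyond the scatter. Compound 3 is expected to give 70000 nM, with a range from 25000 nM to 200000 nM. That estimate corresponds to an expected step of a 1.1-fold lower number from compound 2 to compound 3 (0.04 log units; within the scatter), inside the scatter.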

Compound 3, half-maximal effective concentration: 3900 nM
Compound 3: the middle estimate sits 18-fold (1.25 log units) above what was measured, outside the stated range (below it).
By their numbers in this assay, from the lowest: compound 3; then compound 1; then compound 2.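

The far end of the chain, which the earlier pair left untouched, proves to be a sensitive place in this assay: 3-nitrophenyl in place of furan-2-yl on a double-bonded chain carbon bound to a double-bonded chain carbon gives a 19-fold lower number from compound 2 to compound 3 (1.29 log units; beyond the scatter), a large step, whereas the change on the nitrogen gave the modest 2.7-fold higher number from compound 1 to compound 2 (0.43 log units; beyond the scatter), in the opposite direction. The replacement changes several things at once, since one five-membered aromatic ring with 1 hetero atom leaves and one six-membered aromatic ring of carbon only enters, carrying the nitro group, so this single step cannot assign the drop in the number to the ring or to the nitro group. Nothing at hand explains why this change has so large an effect in these cells.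

A plain phenyl at this end, or a 3-methoxyphenyl or 3-aminophenyl, would show whether the lower number depends on the nitro group or on the benzene ring alone. Going by these compounds, it also remains open whether the 3-nitrophenyl end would give a step of similar size with the free amine of compound 1 or with an acetyl on the nitrogen in place of the benzoyl.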